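The compounds below may be only part of what the source reports. "The series", "measured", "known", "first", "only" and "open" are said of these compounds alone.

Within the data shown here, in a toxicity assay on MT2 cells (Homo sapiens) for cytotoxicity (a lower number here means that less compound is tolerated, a higher number that more compound is tolerated), compound 2 `Cc1cccc(Cl)c1CN1CCc2cc(-c3c(C)nc(C)c([C@H](OC(C)(C)C)C(=O)O)c3N3CCC(C)(C)CC3)ccc2C1` gives 22500 nM, the only actual number so far. Compound 1 `Cc1nc(C)c([C@H](OC(C)(C)C)C(=O)O)c(N2CCC(C)(C)CC2)c1-c1ccc2c(c1)CCN(Cc1ccc(F)cc1)C2` gives >= 22000 nM, which is a limit of the assay and not a number. Compound 3 `Cc1cccc(F)c1CN1CCc2cc(-c3c(C)nc(C)c([C@H](OC(C)(C)C)C(=O)O)c3N3CCC(C)(C)CC3)ccc2C1` departs from compound 2 at a single place: fluoro in place of chloro on an aromatic carbon. Among the measured compounds shown here, only one measured step bears on this change, a step that the limit leaves unreadable from compound 1 to compound 2, and it also concerns the aromatic ring on the saturated chain carbon. Its size cannot be read, and the evidence here amounts to the limit of >= 22000 nM in this assay, at which 1 of the 2 values shown sits. It therefore offers no size to carry over. With compound 2 at 22500 nM as the anchor, no change beyond the scatter is expected in this assay. The expected step is a 1.1-fold higher number from compound 2 to compound 3 (0.03 log units; within the scatter). For compound 3 the estimated value is 24000 nM, with an expected range of 12000 nM to 50000 nM.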

Compound 3, half-maximal cytotoxic concentration: >= 24000 nM
Compound 3: no number, only a limit (the forecaster's own chance of this, stated with the estimate: 35%); the middle value sits exactly at the limit.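

In this assay, fluoro in place of chloro on this aromatic carbon gives a step that can be read, unlike the earlier pair: an at least 1.0-fold higher number from compound 2 to compound 3 (0.02 log units; that floor lies within the scatter). From the compounds shown here alone, compound 3 gives >= 24000 nM, which is a limit of the assay and not a number, so this step is only a floor and the true distance between compound 2 and compound 3 stays unknown. Chloro and fluoro at this place, ortho to a large group, therefore cannot be told apart in this read-out, and the steps from compound 1 to the other two compounds cannot be read.

Going by these compounds, whether this aromatic carbon matters at all for the tolerated concentration stays open. A methoxy group or an amine at this place would test that, but only if the value falls within the measurable range.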